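Aryl ether variation on a shared triazine core

This account rests on a few compounds, and the source may have more. Where it says the series, first, only, none or still open, it means among the compounds named here.

Compound 1 `CN1CCN(c2nc(N)nc(COc3ccccc3)n2)CC1`: 507 nM
Compound 2 `Cc1ccc(OCc2nc(N)nc(N3CCN(C)CC3)n2)cc1`: 235 nM
Compound 3 `CN1CCN(c2nc(N)nc(COc3ccc(Cl)cc3Cl)n2)CC1`: 128 nM

Among the measured compounds shown here, in an assay on HEK293 cells for displacement of a labelled ligand from 5-hydroxytryptamine receptor 6 (Homo sapiens), read by radioligand binding, with a stated time of 1 h (on this read-out lower numbers stand for stronger inhibition and higher numbers for weaker inhibition), compound 3 gives the lowest number of the three, though its gap to compound 2 is within the scatter; only the step of a 4.0-fold lower number from compound 1 to compound 3 (0.60 log units; beyond the scatter) is beyond it. Compound 4 `Cc1cc(OCc2nc(N)nc(N3CCN(C)CC3)n2)ccc1Cl` is compound 3 with 4-chloro-3-methylphenyl in place of 2,4-dichlorophenyl on an oxygen on a saturated carbon. For the measured compounds named here, two measured steps bear on this: a 1.8-fold lower number from compound 2 to compound 3 (0.26 log units; within the scatter) shows that exchanging one substituted phenyl for another moved the number little, while a 2.2-fold lower number from compound 1 to compound 2 (0.33 log units; beyond the scatter) shows a modest gain from a methyl on the aromatic ring. Compound 4 keeps a chlorine and adds a methyl, so no change beyond the scatter is expected; the estimated step is a 1.2-fold higher number from compound 3 to compound 4 (0.07 log units; within the scatter). Compound 4 is therefore expected to give about 150 nM in this assay, within 60 nM to 400 nM.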

Compound 4, inhibition constant: 355 nM
For compound 4 the middle estimate is 2.4-fold (0.37 log units) below the measured one; the measured number falls inside the stated range.
By their numbers in this assay, from the lowest: compounds 3, 2, 4 and 1 (each within the scatter of the next, the first and the last beyond it).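

Among the compounds shown here, at this position, on an oxygen on a saturated carbon, substituted phenyl groups are not always interchangeable: in this assay, 4-chloro-3-methylphenyl in place of 2,4-dichlorophenyl gives a 2.8-fold higher number from compound 3 to compound 4 (0.44 log units; beyond the scatter), the first such exchange to pass the scatter. The same group stays within the scatter of both 4-methylphenyl, with a 1.5-fold higher number from compound 2 to compound 4 (0.18 log units; within the scatter), and unsubstituted phenyl, with a 1.4-fold lower number from compound 1 to compound 4 (0.15 log units; within the scatter). Nothing available here explains this difference.

Still open, as far as these compounds go, is how an amine or a carboxylic acid on the aromatic ring would compare with these groups. From the compounds shown here alone, a longer chain carrying the oxygen is equally open.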